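A few compounds are considered here, and "the series" means these few. Any claim that something is new, unique, unknown or untested is made for them only; others in the source may bear on it.

Compounds measured so far, with their values:

compound 1, `CN(C)CCn1cnnc1-c1cc(Oc2ccc(NC(=O)N/N=C/c3ccc(Cl)cc3Cl)cc2F)ccn1` — 2330 nM
compound 2, `COc1ccc(/C=N/NC(=O)Nc2ccc(Oc3ccnc(-c4nncn4CCN(C)C)c3)c(F)c2)c(OC)c1` — 12600 nM

Both were read in a functional assay on U-87MG ATCC cells (Homo sapiens) for cytotoxicity, read by MTT assay, with a stated time of 72 h; on this read-out higher numbers stand for weaker inhibition and lower numbers for stronger inhibition. On the two numbers available, compound 2 stands highest; its nearest neighbour is compound 1, and the step between them is the only one measured: a 5.4-fold higher number from compound 1 to compound 2 (0.73 log units; beyond the scatter). For the measured compounds named here, that step changed the group on the carbon with a double bond to nitrogen, and it is the one measured step that bears on the next compound.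

Compound 3, `CN(C)CCn1cnnc1-c1cc(Oc2ccc(NC(=O)N/N=C/c3c(O)ccc4ccccc34)cc2F)ccn1`, is not yet measured. It differs from compound 2 in one place: 2-hydroxynaphthalen-1-yl in place of 2,4-dimethoxyphenyl on a carbon with a double bond to nitrogen. Going by the values given here, the change is at the same position as the single measured step, so that step gives the only scale for what to expect. Among the compounds with values here, the move from compound 1 to compound 2 went to a higher number; the move to compound 3 replaces the group that gave the higher number, so a step back toward the number of compound 1 is the expectation, though the new group has no measured precedent here. Compound 3 is therefore expected to show a 3.2-fold lower number from compound 2 to compound 3 (0.50 log units; beyond the scatter), with an estimated value of 4000 nM and a range from 1200 nM to 13000 nM.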

Compound 3, half-maximal inhibitory concentration: 620 nM
The estimate for compound 3 lay 6.5-fold (0.81 log units) above the measured number; the measured number lies below the stated range.
By their numbers in this assay, from the lowest: compound 3; then compound 1; then compound 2.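

In this assay, this position on a carbon with a double bond to nitrogen can give a number lower than either substituted phenyl group shown. 2-Hydroxynaphthalen-1-yl produces a 20-fold lower number from compound 2 to compound 3 (1.31 log units; beyond the scatter) against 2,4-dimethoxyphenyl and a 3.8-fold lower number from compound 1 to compound 3 (0.57 log units; beyond the scatter) against 2,4-dichlorophenyl, so compound 3 now stands lowest of the three, with both steps beyond the scatter. The step from 2,4-dimethoxyphenyl changes several counted features at once, going from one six-membered aromatic ring of carbon only to 2 and from 0 hydrogen-bond donors to 1, and no information is available to explain the drop.

The compounds shown leave open whether the hydroxyl, the second aromatic ring or their combination accounts for the lower number; naphthalen-1-yl without the hydroxyl, 2-hydroxyphenyl and 2-methoxynaphthalen-1-yl at this place would separate these contributions. They also leave open whether 2-hydroxynaphthalen-1-yl would give a similar step if the dimethylaminoethyl chain of the shared core were replaced by a morpholine-bearing chain.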